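From chloro to methyl at compound 3

The source may hold more compounds than are shown below. What is called first, only, known or untested is meant among the compounds shown, and "the series" means these compounds.

- Compound 1 (`COc1ccc([C@H]2CC(=O)N(c3cccc(C#N)c3)C2)cc1OC1CCCC1`) gives > 10000 nM as a limit
- Compound 2 (`COc1ccc([C@H]2CC(=O)N(c3cccc(NS(=O)(=O)c4ccccc4Cl)c3)C2)cc1OC1CCCC1`) gives > 10000 nM as a limit

Both entries come from a functional assay on HEK293 cells (Homo sapiens) for cytotoxicity (a lower number here means that less compound is tolerated, a higher number that more compound is tolerated), and neither is an exact number. Compound 2 stands at the limit of > 10000 nM in this assay, at which 2 of the 2 values shown sit, and has no exact value of its own.

Among the measured compounds shown here, the one measured step is a step that the two limits leave unreadable from compound 1 to compound 2 and in it ((2-chlorophenyl)sulfonyl)amino takes the place of cyano on an aromatic carbon. For the measured compounds named here, its size cannot be read, and no measured step covers the exchange that comes next.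

Compound 3 (`COc1ccc([C@H]2CC(=O)N(c3cccc(NS(=O)(=O)c4ccccc4C)c3)C2)cc1OC1CCCC1`) differs from compound 2 in a single group: methyl in place of chloro on an aromatic carbon with methyl in place of chloro, on an aromatic carbon of a six-membered aromatic ring of carbon only, ortho to a large group.

With so little to go on, no change beyond the usual scatter is expected in this assay and no direction can be named. The expected step is a step that the limit leaves unreadable from compound 2 to compound 3 within that scatter. For compound 3 the estimated half-maximal cytotoxic concentration is 12000 nM with an expected range of 7000 nM to 25000 nM and another limit is the likeliest report.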

Compound 3, half-maximal cytotoxic concentration: > 10000 nM
Compound 3 gave a limit, no number (the forecaster's own chance of this, stated with the estimate: 85%); the middle value lies beyond the limit too.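

In this assay, among the compounds shown here, compound 3 gives a limit and not a number, as compound 1 and compound 2 do, so no step among the three can be read, and all three stand at one mark: the limit of > 10000 nM in this assay, at which 3 of the 3 values shown sit. Left open is how much of each compound is tolerated beyond that limit, and whether methyl in place of chloro changes it at all.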